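The source may report more compounds than this note shows. Statements on the series, on what has been measured and on what is new or still open speak of the compounds shown alone.

Measured in an ADME assay on HepG2 2.2.15 cells (Homo sapiens) for cytotoxicity; on this read-out higher numbers stand for lower toxicity in this test and lower numbers for higher toxicity in this test:
- Compound 1 `O=c1[nH]c2ccc(Cl)cc2c(-c2ccccc2Cl)c1CCO`: 380000 nM
- Compound 2 `CCCCC(=O)OCCc1c(-c2ccccc2Cl)c2cc(Cl)ccc2[nH]c1=O`: 200000 nM
- Compound 3 `COCC(=O)OCCc1c(-c2ccccc2Cl)c2cc(Cl)ccc2[nH]c1=O`: 74000 nM

Compound 3 holds the lowest of the three numbers, and its gaps to both other compounds lie beyond the scatter. Compound 4 `CC12CCC(C(=O)OCCc3c(-c4ccccc4Cl)c4cc(Cl)ccc4[nH]c3=O)(OC1=O)C2(C)C` differs from compound 3 in the group on a carbonyl carbon: a group of 11 heavy atoms (9 carbon, 2 oxygen; one five-membered non-aromatic ring of carbon only, one five-membered non-aromatic ring with 1 hetero atom) in place of a group of 3 heavy atoms (2 carbon, 1 oxygen; no ring), on a carbonyl carbon.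

Within the data shown here, three measured steps bear on this change. The first, a 1.9-fold lower number from compound 1 to compound 2 (0.28 log units; within the scatter), stays within the scatter. The second, a 5.1-fold lower number from compound 1 to compound 3 (0.71 log units; beyond the scatter), is modest, and so is the third, a 2.7-fold lower number from compound 2 to compound 3 (0.43 log units; beyond the scatter). Only the third changes the same place as the new step, and it is the closest guide. Among the measured compounds shown here, no measured compound carries the entering group or any ring at this place, so the size of the step remains uncertain. Like compound 4, compound 2 has no methoxymethyl, and compound 2 stands at 200000 nM. A small move towards a higher number is therefore expected, and no step beyond the scatter is expected: the estimated step is a 1.6-fold higher number from compound 3 to compound 4 (0.21 log units; within the scatter). Compound 4 is expected at 120000 nM, with an estimated range from 45000 nM to 300000 nM.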

Compound 4, half-maximal cytotoxic concentration: > 1800000 nM
Compound 4 was reported as a limit; the forecaster's own chance of this, stated with the estimate: 15%; at least 15-fold (1.17 log units) between middle value and limit.
By their numbers in this assay, from the lowest: compound 3; then compounds 2 and 1 (each within the scatter of the next). At a limit, above all of these: compound 4.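

In this assay compound 4 is reported only as a limit, not as a number: the limit of > 1800000 nM in this assay, at which 1 of the 4 values shown sits. On the carbonyl carbon, the group of 11 heavy atoms with its two five-membered non-aromatic rings gives an at least 24-fold higher number from compound 3 to compound 4 (1.38 log units; beyond the scatter), and against the open-chain ester of compound 2 it gives an at least 9.0-fold higher number from compound 2 to compound 4 (0.95 log units; beyond the scatter), both beyond the scatter. Among these compounds, the earlier compounds carried no ring at this place, and their exchange of groups on this carbonyl carbon gave only a 2.7-fold lower number from compound 2 to compound 3 (0.43 log units; beyond the scatter), so the new result shows for the first time that a change here can move this read-out by a large step, in the direction of lower toxicity in this test.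

As far as these compounds go, with compound 4 given only as a limit, the full size of both steps stays unknown, and this single entering group cannot separate the effect of its two rings from that of its heavy-atom count or its added oxygen. From the compounds shown here alone, how an amine, a carboxylic acid, a longer chain or a simple carbon-only ring on this carbonyl carbon would read also remains open.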